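From an Aromatic Ring to a Saturated Ring at the Core

This account rests on a few compounds, and the source may have more. Where it says the series, first, only, none or still open, it means among the compounds named here.

Compound 3 `FC(F)(F)c1ccc(Nc2cc3[nH]c(-c4cccc(C(F)(F)F)c4)nc3cn2)nc1` stands highest of the three compounds measured in an ADME assay on microsomes from liver (Homo sapiens) for metabolic stability, read by LC-MS, with a stated time of 30 min, tested at 0.1 uM (on this read-out lower numbers stand for a less stable compound and higher numbers for a more stable compound), where compound 3 gives 90%. Its nearest neighbour is compound 1 `COc1cccnc1Nc1cc2[nH]c(-c3cccc(C(F)(F)F)c3)nc2cn1`, which gives 69%; compound 2 `Fc1cnc(Nc2cc3[nH]c(-c4cccc(C(F)(F)F)c4)nc3cn2)c(F)c1` lies furthest, with 32%. The corresponding steps are a number 21 percentage points higher from compound 1 to compound 3 (beyond the scatter) and a number 58 percentage points higher from compound 2 to compound 3 (beyond the scatter). Compound 4 `FC1(F)CCC(c2nc3cnc(Nc4ccc(C(F)(F)F)cn4)cc3[nH]2)CC1` differs from compound 3 in one place, (4,4-difluorocyclohexyl in place of 3-(trifluoromethyl)phenyl on an aromatic carbon). Every measured step changes the group on a nitrogen on an aromatic ring, not this aromatic carbon, so none bears directly on the new change; those steps show only how widely this read-out can move. The estimate for compound 4 is therefore held loosely: a value of 72%, within 40% to 95%, is expected. That corresponds to an expected step of a number 18 percentage points lower from compound 3 to compound 4 (beyond the scatter).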

Compound 4, percent of the compound remaining: 99%
Beside the measured number, compound 4's estimate is 27 percentage points below it, and the stated range ends below it.
By their numbers in this assay, from the lowest: compound 2; then compound 1; then compounds 3 and 4 (each within the scatter of the next).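

At the aromatic carbon between two ring nitrogen atoms, 4,4-difluorocyclohexyl in place of 3-(trifluoromethyl)phenyl gives a number 9 percentage points higher from compound 3 to compound 4 (within the scatter) in this assay. Within the data shown here, this is the first measured change at this position, and it shows that, for this pair, a non-aromatic ring there fits a number as high as the aromatic ring does. Nothing measured here explains this result. The compounds shown leave open whether a plain cyclohexyl without fluorine, a piperidine ring with its amine nitrogen, or an open propyl chain would read the same at this place.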